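Inverting the core of an MCH receptor 1 antagonist

This account rests on a few compounds, and the source may have more. Where it says the series, first, only, none or still open, it means among the compounds named here.

Of the compounds shown here, two have numbers so far. Compound 1 `NCc1ncc([C@]23CC[C@@H](N(CCN4CC[C@H](O)C4)C(=O)Nc4ccc(F)c(C(F)(F)F)c4)C2C3)s1` gives 99 nM in a functional assay for antagonist activity at melanin-concentrating hormone receptor 1 (Homo sapiens); on this read-out higher numbers stand for weaker inhibition and lower numbers for stronger inhibition. Compound 2 `C[C@@H]1CN(CCCN(C(=O)Nc2cc(Cl)nc(Cl)c2)[C@H]2CC[C@@]3(c4cnc(CN)s4)C[C@@H]23)[C@@H](C)CN1` gives 117 nM in this assay, the higher of the two numbers, yet within the scatter of compound 1. Compound 3 `C[C@@H]1CN[C@@H](C)CN1CCCN(C(=O)Nc1cc(Cl)nc(Cl)c1)[C@H]1CC[C@]2(c3cnc(CN)s3)C[C@H]12` is not yet measured; its difference from compound 2 is the two compounds have the same atoms and bonds and differ only in configuration as drawn: 4 of 5 stereo elements differ; a stereocentre at a saturated ring carbon is drawn S in compound 2 and R in compound 3; a stereocentre at a saturated ring carbon is drawn R in compound 2 and S in compound 3; a stereocentre at a saturated ring carbon is drawn R in compound 2 and S in compound 3; a stereocentre at a saturated ring carbon is drawn R in compound 2 and S in compound 3. Going by the values given here, no step between measured compounds covers such an inversion, so the expectation rests on the change alone: a clearly weaker result is expected, with a step of a 6.8-fold higher number from compound 2 to compound 3 (0.83 log units; beyond the scatter) beyond the scatter. For compound 3 the expected value is 800 nM, within a range from 150 nM to 5000 nM.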

Compound 3, inhibition constant: 4 nM
Compound 3: the middle estimate sits 200-fold (2.30 log units) above what was measured; the whole stated range lies above it.
By their numbers in this assay, from the lowest: compound 3; then compounds 1 and 2 (each within the scatter of the next).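

The step in this assay is a 29-fold lower number from compound 2 to compound 3 (1.47 log units; beyond the scatter), and it can only come from configuration because nothing else separates the pair: the fact that compounds 2 and 3 differ only in the configuration as drawn. Compounds 1 and 2 gave no view of this, whereas this pair shows that the way the atoms are arranged in space can matter at this receptor as much as the atoms themselves.

From the compounds shown here alone, four stereocentres change together, so which of them carries the gain remains open. Also open, going by these compounds, is whether the same inversion gives a similar step when a morpholine replaces the dimethylpiperazine.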